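Phenoxy in place of hydroxy at the shared core

A few compounds are considered here, and "the series" means these few. Any claim that something is new, unique, unknown or untested is made for them only; others in the source may bear on it.

Of the compounds shown here, two have been measured. Compound 1 `COc1ccc(C2C(O)C(=O)N2c2cc(OC)c(OC)c(OC)c2)cc1` gives 13 nM in a functional assay on HL-60 cells (Homo sapiens) for inhibition, read by resazurin assay, with a stated time of 72 h; on this read-out higher numbers stand for weaker inhibition and lower numbers for stronger inhibition. Compound 2 `COc1cc(N2C(=O)C(O)C2c2ccc(SC)cc2)cc(OC)c1OC` gives 15 nM in this assay; the difference, methylsulfanyl in place of methoxy on an aromatic carbon, is a 1.2-fold higher number from compound 1 to compound 2 (0.06 log units; within the scatter), so the two numbers sit alongside each other and compound 2 stands level with compound 1.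

Compound 3 `COc1cc(N2C(=O)C(Oc3ccccc3)C2c2ccc(SC)cc2)cc(OC)c1OC` differs from compound 2 by phenyl in place of hydrogen on an oxygen on a saturated carbon. Going by the values given here, no measured step touches this oxygen: the single step known concerns the aromatic carbon, and its size is a 1.2-fold higher number from compound 1 to compound 2 (0.06 log units; within the scatter), so it gives no guide to what the new phenyl will do. The expectation rests on the change alone, and the estimate is kept wide. The expected step is a 4.0-fold higher number from compound 2 to compound 3 (0.60 log units; beyond the scatter), toward weaker inhibition. Compound 3 is therefore estimated at 60 nM in this assay, within 12 nM to 400 nM.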

Compound 3, half-maximal inhibitory concentration: 388 nM
For compound 3 the middle estimate is 6.5-fold (0.81 log units) below the measured one; the measured number falls inside the stated range.
By their numbers in this assay, from the lowest: compounds 1 and 2 (each within the scatter of the next); then compound 3.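

In this assay, going by these compounds alone, hydroxy to phenoxy on the saturated ring carbon gives a large step toward weaker inhibition (a 26-fold higher number from compound 2 to compound 3 (1.41 log units; beyond the scatter)), the first step beyond the scatter. Within the data shown here, this position is therefore not indifferent to change, whereas the only earlier step, methylsulfanyl in place of methoxy on an aromatic carbon, stayed within the scatter (a 1.2-fold higher number from compound 1 to compound 2 (0.06 log units; within the scatter)). Nothing available bears on why the step from hydrogen to phenyl on this oxygen is so large.

Only hydrogen and phenyl are shown on this oxygen, so it remains open whether any group there costs this much or whether the size of the step belongs to the phenyl ring itself; a methyl ether, a benzyl ether or an acetate would separate these cases. Also open, as far as these compounds go, is whether an amine in place of the hydroxy is tolerated, and whether phenoxy has the same effect alongside the methoxy of compound 1.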